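The source may hold more compounds than are shown below. What is called first, only, known or untested is meant among the compounds shown, and "the series" means these compounds.

Four compounds are compared here, built on two closely related cores. Compound 1 `CC[C@@H]1C(=O)N(C)c2cnc(-n3ccc4cc(C(=O)NCC(C)C)ccc43)nc2N1C1CCCC1` and compound 3 `CC[C@@H]1C(=O)N(C)c2cnc(-n3ccc4cc(C(=O)NC5CCCC5)ccc43)nc2N1C1CCCC1` share one core; compound 2 `CCC1C(=O)N(C)c2cnc(-n3ccc4cc(C(=O)NCC(C)C)ccc43)nc2N1c1ccn(C)n1` and compound 4 `CCC1C(=O)N(C)c2cnc(-n3ccc4cc(C(=O)NC5CCCC5)ccc43)nc2N1c1ccn(C)n1` share a second, and the difference between the two cores is not broken down here. In an assay for inhibition of serine/threonine-protein kinase PLK2 (Homo sapiens), read by FRET and Z'-LYTE, with a stated time of 1 h (on this read-out higher numbers stand for weaker inhibition and lower numbers for stronger inhibition), compound 1 gives 18.6 nM, and compound 3 gives 7.06 nM. Going by the values given here, compound 2 gives 159 nM, the highest of the three numbers measured so far; the values alone show compound 2 standing well above compound 1 and compound 3.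

Within the first core, the single change is cyclopentyl in place of isobutyl on an amide-type nitrogen, and it produced a 2.6-fold lower number from compound 1 to compound 3 (0.42 log units; beyond the scatter). Compound 4 differs from compound 2 by the same change, (cyclopentyl in place of isobutyl on an amide-type nitrogen), at the same place, so the two pairs test the same move on two different cores.

The step from compound 2 to compound 4 is expected to be a 2.6-fold lower number from compound 2 to compound 4 (0.42 log units; beyond the scatter), a size that rests on the measured step of a 2.6-fold lower number from compound 1 to compound 3 (0.42 log units; beyond the scatter) for the identical change on the first core. That measured step comes from a single pair, and whether the second core responds in the same way is not known, so the range is kept wide. Compound 4 is estimated to give about 61 nM in this assay, with the likely span running from 30 nM to 125 nM.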

Compound 4, half-maximal inhibitory concentration: 90.9 nM
For compound 4 the middle estimate is 1.5-fold (0.17 log units) below the measured one; measured number inside the range.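

In this assay, putting cyclopentyl in place of isobutyl on the amide-type nitrogen of the second core gives a 1.7-fold lower number from compound 2 to compound 4 (0.24 log units; within the scatter), so this step taken alone cannot be told apart from the ordinary spread of repeated measurements. Set beside the step on the first core, the two results do not differ by more than that spread: the same change on two cores in this assay, a 2.6-fold lower number (0.42 log units; beyond the scatter) from compound 1 to compound 3 and a 1.7-fold lower number (0.24 log units; within the scatter) from compound 2 to compound 4, 1.5-fold (0.18 log units) apart, within the scatter of two such steps This agrees with the change carrying over from one core to the other, but it rests on only two pairs, and the step on the second core is too small to confirm on its own, so it does not show that the swap reliably gives a real gain on every core in this series.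

The compounds shown leave open how other groups on the amide-type nitrogen would behave, such as a cyclohexyl ring, a longer straight chain or a chain ending in an amine or a carboxylic acid. They also leave open which part of the difference between the two cores accounts for the gap between their values, and whether the cyclopentyl-for-isobutyl swap would hold on a third core.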